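This account rests on a few compounds, and the source may have more. Where it says the series, first, only, none or still open, it means among the compounds named here.

Measured so far in a functional assay on A549 cells (Homo sapiens) for cytotoxicity, read by MTT assay, with a stated time of 48 h; a higher number here means a weaker inhibitor, a lower number a stronger inhibitor:
compound 1 (`CC1(C)CCC[C@]2(C)[C@@H](CC[C@@](C)(O)/C=C/c3ccccc3)[C@](C)(O)CC[C@@H]12`): 3150 nM
compound 2 (`Cc1cccc(C)c1/C=C/[C@](C)(O)CC[C@@H]1[C@@]2(C)CCCC(C)(C)[C@@H]2CC[C@@]1(C)O`): 3340 nM

Compound 2 stands at 3340 nM and cannot be told apart from compound 1 within the scatter. Compound 3 (`CC1(C)CCC[C@]2(C)[C@@H](CC[C@@](C)(O)/C=C/c3ccc(Br)cc3)[C@](C)(O)CC[C@@H]12`) is not yet measured. It differs from compound 2 in one group (4-bromophenyl in place of 2,6-dimethylphenyl on a double-bonded chain carbon bound to a double-bonded chain carbon), with 4-bromophenyl in place of 2,6-dimethylphenyl on a double-bonded chain carbon bound to a double-bonded chain carbon. For the measured compounds named here, the one measured step at this place, 2,6-dimethylphenyl in place of phenyl, is small and lies within the scatter (a 1.1-fold higher number from compound 1 to compound 2 (0.03 log units; within the scatter)). Going by the values given here, no measured compound carries 4-bromophenyl, so this evidence is thin. No step beyond the scatter is therefore expected in this assay (a 1.2-fold lower number from compound 2 to compound 3 (0.08 log units; within the scatter)). Compound 3 is estimated to give a value near 2800 nM (expected range 1100 nM to 7000 nM).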

Compound 3, half-maximal inhibitory concentration: 43200 nM
Estimate against measurement, compound 3: 15-fold (1.19 log units) below; the whole stated range lies below it.
By their numbers in this assay, from the lowest: compounds 1 and 2 (each within the scatter of the next); then compound 3.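

In this assay the aryl group on this double-bonded chain carbon is not freely interchangeable: bromo in place of hydrogen on an aromatic carbon gives a 14-fold higher number from compound 1 to compound 3 (1.14 log units; beyond the scatter) and marks a single-group change as enough to shift the read-out well beyond the scatter. The swap of 2,6-dimethylphenyl for 4-bromophenyl gives a 13-fold higher number from compound 2 to compound 3 (1.11 log units; beyond the scatter) in the same direction, so the tolerance seen with 2,6-dimethylphenyl does not extend to 4-bromophenyl, even though both groups hold one six-membered aromatic ring of carbon only. No data at hand bear on the cause of this large step.

Going by these compounds, it remains open whether the step is specific to bromo or follows from any group at that ring carbon. Chloro, fluoro, methyl or methoxy in place of bromo in the 4-substituted phenyl group would separate these readings.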